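This account rests on a few compounds, and the source may have more. Where it says the series, first, only, none or still open, it means among the compounds named here.

Of the compounds shown here, two that share one core have been tested in an assay on cells (Oocyte) for negative allosteric modulation of glutamate receptor ionotropic, NMDA 2D (Rattus norvegicus), read by two-electrode voltage clamp; on this read-out lower numbers stand for stronger inhibition and higher numbers for weaker inhibition. Compound 1 `O=C(O)CCC(=O)N1N=C(c2c(-c3ccccc3)c3cc(Cl)ccc3[nH]c2=O)CC1c1ccc([N+](=O)[O-])cc1` gives 1100 nM in this assay. Compound 2 `Cc1ccc(-c2c(C3=NN(C(=O)CCC(=O)O)C(c4ccc(Cl)cc4)C3)c(=O)[nH]c3ccccc23)cc1` gives 1400 nM in this assay, and the gap between compound 2 and compound 1 lies within the usual scatter of repeated measurements, so the two stand level with each other. Compound 3 `COc1cccc(-c2c(C3=NN(C(=O)CCC(=O)O)C(c4ccc(Cl)cc4)C3)c(=O)[nH]c3ccccc23)c1` has not been measured. It differs from compound 2 in one place: 3-methoxyphenyl in place of 4-methylphenyl on an aromatic carbon. Within the data shown here, no measured pair in this set changes that group, so nothing in the numbers points to a large shift in either direction. The step is therefore expected to be small and to stay within the scatter, at a 1.1-fold higher number from compound 2 to compound 3 (0.03 log units; within the scatter). Compound 3 is estimated to give 1500 nM in this assay, with a likely range from 600 nM to 4000 nM.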

Compound 3, half-maximal inhibitory concentration: 4500 nM
Estimate against measurement, compound 3: 3.0-fold (0.48 log units) below, and the stated range ends below it.
By their numbers in this assay, from the lowest: compounds 1 and 2 (each within the scatter of the next); then compound 3.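

In this assay, the group on this aromatic carbon turns out to matter: putting 3-methoxyphenyl in place of 4-methylphenyl gives a 3.2-fold higher number from compound 2 to compound 3 (0.51 log units; beyond the scatter), which means weaker inhibition. Among these compounds, this is the only step in the set that changes a single place, so it gives the first direct sign that the read-out responds to what this ring carries, something the differing compounds 1 and 2 could not show. No measurement at hand explains why the number rises.

The step changes both the place of the substituent on the ring and its kind, so 3-methylphenyl and 4-methoxyphenyl are the groups that would separate these two effects. Also open, on these data alone, is how an unsubstituted phenyl or an aminophenyl would behave here, with the rest of compound 2 unchanged.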